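Sulfonyl aryl swap on a quinoline-type piperidine series

This account rests on a few compounds, and the source may have more. Where it says the series, first, only, none or still open, it means among the compounds named here.

Compound 1 `CC1CCN(c2c(S(=O)(=O)c3cc(F)cc(F)c3)cnc3cc(Cl)ccc23)CC1`: in an assay on isolated protein for displacement of a labelled ligand from metabotropic glutamate receptor 5 (Homo sapiens), with a stated time of 60 min, tested at 1 uM (on this read-out higher numbers stand for more inhibition at the one concentration tested (going by the name of the read-out) and lower numbers for less inhibition), compound 1 gives 94%.
Compound 2 `CC1CCN(c2c(S(=O)(=O)c3cc(F)cc(F)c3)cnc3cc(F)ccc23)CC1`: compound 2 gives 77%.
Compound 3 `NC(=O)C1CCN(c2c(S(=O)(=O)c3ccccc3)cnc3ccccc23)CC1`: compound 3 gives 24.8%.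

Compound 1 stands highest of the three, with compound 2 nearest and compound 3 furthest behind. Within the data shown here, the only single-place step recorded is a number 17 percentage points lower from compound 1 to compound 2 (beyond the scatter), fluoro in place of chloro on an aromatic carbon of the shared core.

Compound 4 `CC1CCN(c2c(S(=O)(=O)c3cccc(Cl)c3)cnc3cc(Cl)ccc23)CC1` differs from compound 1 at another site: 3-chlorophenyl in place of 3,5-difluorophenyl on a sulfonyl sulfur. Among the measured compounds shown here, no measured step touches the aryl group on the sulfonyl sulfur; compound 3 carries a plain phenyl there but also differs elsewhere, so its value cannot be read as a step. The change is small, and compound 4 is therefore expected to stay near compound 1, with a step of a number 9 percentage points lower from compound 1 to compound 4 (within the scatter), within or just beyond the scatter. Compound 4 is estimated at 85%, between 65% and 98%.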

Compound 4, a percentage reported as inhibition, at one concentration (the size of the read-out at that concentration, not a potency): 92%
Compound 4: the middle estimate sits 7 percentage points below what was measured, and the stated range covers the measured number.
By their numbers in this assay, from the lowest: compound 3; then compound 2; then compounds 4 and 1 (each within the scatter of the next).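

Among these compounds, on the sulfonyl sulfur, 3-chlorophenyl in place of 3,5-difluorophenyl is the first readable change at this position in this assay, and it gives a number 2 percentage points lower from compound 1 to compound 4 (within the scatter). Unlike the earlier step on the shared core (a number 17 percentage points lower from compound 1 to compound 2 (beyond the scatter)), this aryl swap shows no difference beyond the scatter. Nothing measured here offers a reason for this result. Going by these compounds, what stays open is whether the same swap would hold on the core of compound 2, and whether the number in this assay would be higher, lower or level with an aryl group bearing an amine or a carboxylic acid on the sulfonyl sulfur.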